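Methoxy for chloro in a ring-opened analogue series

The compounds below may be only part of what the source reports. "The series", "measured", "known", "first", "only" and "open" are said of these compounds alone.

The study covers four compounds in two pairs. Compound 1 `COc1ccc(C23CCC(=O)N2CCCO3)cc1` and compound 2 `O=C1CCC2(c3ccc(Cl)cc3)OCCCN12` share one core, while compound 3 `O=C(CCC(=O)c1ccc(Cl)cc1)NCCCO` and compound 4 `COc1ccc(C(=O)CCC(=O)NCCCO)cc1` share an open-chain core; how the core of compound 2 differs from that of compound 3 is not broken down here.

In a functional assay on the whole organism with Mus musculus as the target (on this read-out lower numbers stand for an effect already at smaller amounts and higher numbers for an effect only at larger amounts of compound), compound 2 gives 91.7 mg/kg. In this assay compound 1 gives 139 mg/kg. Compound 1 differs from compound 2 by methoxy in place of chloro on an aromatic carbon, and this change made a step of a 1.5-fold higher number from compound 2 to compound 1 (0.18 log units; within the scatter), so the two values are indistinguishable within the usual scatter. Compound 3 reaches only a limit of > 300 mg/kg in this assay, a limit and not a number. This is the limit of > 300 mg/kg in this assay, at which 1 of the 3 values shown sits.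

Among the compounds with values here, compound 4 differs from compound 3 by methoxy in place of chloro on an aromatic carbon, the same change as the one between compound 2 and compound 1, at a place described in the same words. Compound 4 is therefore expected to give 400 mg/kg in this assay, with a range from 150 mg/kg to 1000 mg/kg. The expected step is a step that the limit leaves unreadable from compound 3 to compound 4, and this expectation rests on the step of a 1.5-fold higher number from compound 2 to compound 1 (0.18 log units; within the scatter), which lies within the scatter, together with the fact that compound 3 reached only a limit. It is therefore judged likely that compound 4 also returns only a limit rather than a number.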

Compound 4, dose for half-maximal effect: > 600 mg/kg
Compound 4 was reported as a limit; the forecaster's own chance of this, stated with the estimate: 70%; middle value at least 1.5-fold (0.17 log units) from the limit.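

In this assay compound 3 gives > 300 mg/kg, which is a limit and not a number. Compound 4 gives > 600 mg/kg, which is also a limit and not a number. Within the data shown here, no step can therefore be read from compound 3 to compound 4. The compounds shown leave open how far methoxy in place of chloro on an aromatic carbon shifts the read-out in the open-chain pair.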